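A few compounds are considered here, and "the series" means these few. Any claim that something is new, unique, unknown or untested is made for them only; others in the source may bear on it.

Of the compounds shown here, three sharing one core have been measured in an assay on cells for displacement of a labelled ligand from adenosine receptor A2b (Homo sapiens), read by scintillation counting and radioligand binding, with a stated time of 30 min, tested at 10 uM; on this read-out higher numbers stand for more inhibition at the one concentration tested (going by the name of the read-out) and lower numbers for less inhibition. Compound 1 `CN1CCN(c2nc(-c3cccc(Cl)c3)nc3[nH]cnc23)CC1` gives 29.9%, compound 2 `CN1CCN(c2nc(-c3ccc(Cl)c(Cl)c3)nc3c2ncn3C)CC1` gives 28.3%, and compound 3 `CN1CCN(c2nc(-c3ccccc3O)nc3c2ncn3C)CC1` gives 36%. Compound 3 therefore stands with the other two inside the usual scatter: its gap to compound 1 and its gap to compound 2 both lie within what repeated measurements of this kind would give, so none of the three can be set apart from the others.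

Within the data shown here, the one single-point step among them, a number 7.7 percentage points higher from compound 2 to compound 3 (within the scatter), is within the scatter, so the swap of one aryl group for another on that position left the read-out essentially unchanged.

Compound 4 `CN1CCN(c2nc(-c3cccc(Cl)c3)nc3c2ncn3C)CC1` differs from compound 3 in one place: 3-chlorophenyl in place of 2-hydroxyphenyl on an aromatic carbon. The aryl swap in the measured step bears on this, and its size was within the scatter. Compound 1 also carries a 3-chlorophenyl group, though its core differs from that of compound 4 at a second place, so the value of compound 1, 29.9%, can only hint that this aryl group leaves the read-out in the same region.

Compound 4 is therefore expected to show a step of a number 5 percentage points lower from compound 3 to compound 4 (within the scatter), no larger than the scatter, and its estimated value is 31%, with a range from 19% to 43%.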

Compound 4, a percentage reported as inhibition, at one concentration (the size of the read-out at that concentration, not a potency): 19.2%
Estimate against measurement, compound 4: 11.8 percentage points above; measured number inside the range.
By their numbers in this assay, from the lowest: compounds 4, 2, 1 and 3 (each within the scatter of the next, the first and the last beyond it).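

In this assay, a change of aryl group on this aromatic carbon between two ring nitrogen atoms now gives a readable difference: a number 16.8 percentage points lower from compound 3 to compound 4 (beyond the scatter), whereas the earlier exchange of 3,4-dichlorophenyl for 2-hydroxyphenyl, a number 7.7 percentage points higher from compound 2 to compound 3 (within the scatter), did not. Within the chlorinated aryl groups, the loss of one chloro gives a number 9.1 percentage points lower from compound 2 to compound 4 (within the scatter), so 3,4-dichlorophenyl and 3-chlorophenyl cannot be told apart at this position. The result also shows a second place that can shift the read-out, since methyl in place of hydrogen on the aromatic nitrogen of the core gives a number 10.7 percentage points lower from compound 1 to compound 4 (beyond the scatter), a modest step of about the same order as the aryl change.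

No measurement shown here accounts for the size or direction of these steps. The exchange of 2-hydroxyphenyl for 3-chlorophenyl alters both the substituent and where it sits on the aryl ring, so 2-chlorophenyl and 3-hydroxyphenyl would be needed to separate these two changes, and an ethyl group on the aromatic nitrogen would show whether the step seen with methyl extends to a longer chain.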